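This account rests on a few compounds, and the source may have more. Where it says the series, first, only, none or still open, it means among the compounds named here.

In a functional assay (a higher number here means a weaker inhibitor, a lower number a stronger inhibitor), compound 3 (`CC(C)=CCOc1cc(O)c2c(c1)OC(c1ccc(C)cc1)CC2=O`) gives 4360 nM. Compound 2 (`CC(C)=CCOc1cc(O)c2c(c1)OC(c1ccc(F)cc1)CC2=O`) gives 6060 nM, within the scatter of compound 3. Compound 1 (`COc1ccc(C2CC(=O)c3ccc(OCC=C(C)C)cc3O2)cc1`) gives 10200 nM, a higher number than compound 3 and beyond the scatter.

The next compound is compound 4 (`COc1ccc(C2CC(=O)c3c(O)cc(OCC=C(C)C)cc3O2)cc1`). The change is methoxy in place of methyl on an aromatic carbon, para to a large group, so 4-methylphenyl becomes 4-methoxyphenyl.

Among the measured compounds shown here, one measured step bears directly on this place: a 1.4-fold lower number from compound 2 to compound 3 (0.14 log units; within the scatter), with methyl in place of fluoro. That step is small and stays within the scatter. Compound 1 also carries 4-methoxyphenyl, but its core differs from that of compound 4, so it offers no single-change comparison. For the measured compounds named here, no measured step has methoxy entering here alone, so no step beyond the scatter is expected in either direction.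

The estimated change is a 1.1-fold higher number from compound 3 to compound 4 (0.06 log units; within the scatter), expected to remain within the scatter. In this assay the estimate for compound 4 is 5000 nM, with an expected range of 2200 nM to 11000 nM.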

Compound 4, half-maximal inhibitory concentration: 5080 nM
Beside the measured number, compound 4's estimate is 1.0-fold (0.01 log units) below it; low and high end bracket the measured number.
By their numbers in this assay, from the lowest: compounds 3, 4, 2 and 1 (each within the scatter of the next, the first and the last beyond it).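

In this assay, methoxy at this place, para to a large group, joins methyl and fluoro without separating from either: the readings are a 1.2-fold higher number from compound 3 to compound 4 (0.07 log units; within the scatter) and a 1.2-fold lower number from compound 2 to compound 4 (0.08 log units; within the scatter) and so the three groups cannot be ranked here. Among the compounds shown here, compound 4 also gives the first single-change reading of hydroxy in place of hydrogen on an aromatic carbon, a 2.0-fold lower number from compound 1 to compound 4 (0.30 log units; within the scatter) which leaves that change at the edge of the scatter but not past it. No measured evidence accompanies these steps to account for them.

On these data alone, what an amine, a carboxylic acid or a longer chain at this place would do remains open. Also open, as far as these compounds go, is whether hydroxy in place of hydrogen gives a similar step when 4-methylphenyl replaces 4-methoxyphenyl.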